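A few compounds are considered here, and "the series" means these few. Any claim that something is new, unique, unknown or untested is made for them only; others in the source may bear on it.

Values measured so far in an in vitro ADME assay on microsomes from liver (Mus musculus) for pharmacokinetics, read by LC-MS, with a stated time of 10 min, tested at 1 uM (on this read-out lower numbers stand for slow clearance and higher numbers for fast clearance), are these:
Compound 1 `CN1C[C@H](C(=O)Nc2ccc(C#N)cc2)[C@@H](c2ccc(/C=C/C(=O)Nc3ccccc3N)cc2)C1` gives 35 mL/min/kg
Compound 2 `CN1C[C@H](C(=O)Nc2ccc(C3CC3)cc2)[C@@H](c2ccc(/C=C/C(=O)Nc3ccccc3N)cc2)C1` gives 60 mL/min/kg

Compound 2 (60 mL/min/kg) stands within the scatter of compound 1 (35 mL/min/kg), so the two numbers do not separate the pair. Compound 3 `CN1C[C@H](C(=O)Nc2cccc(Cl)c2)[C@@H](c2ccc(/C=C/C(=O)Nc3ccccc3N)cc2)C1` has not yet been measured. It differs from compound 2 as follows: 3-chlorophenyl in place of 4-cyclopropylphenyl on an amide-type nitrogen.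

Among the measured compounds shown here, only one measured step bears on this change, and only in part. It is a 1.7-fold higher number from compound 1 to compound 2 (0.23 log units; within the scatter) (cyclopropyl in place of cyano on an aromatic carbon). That step altered the same aryl group on the amide-type nitrogen and did not leave the scatter. For the measured compounds named here, no measured compound carries 3-chlorophenyl, so the direction of the new step is poorly supported, and the expectation leans only slightly towards the middle of the two measured numbers. The expected step is a 1.3-fold lower number from compound 2 to compound 3 (0.12 log units; within the scatter) (nothing beyond the scatter is expected). Compound 3 is estimated at 45 mL/min/kg (expected range 22 mL/min/kg to 90 mL/min/kg).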

Compound 3, clearance: 58 mL/min/kg
Compound 3: middle estimate off by 1.3-fold (0.11 log units), on the low side, within the range that was stated.
By their numbers in this assay, from the lowest: compounds 1, 3 and 2 (each within the scatter of the next).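

In this assay, 3-chlorophenyl in place of 4-cyclopropylphenyl on the amide-type nitrogen gives a 1.0-fold lower number from compound 2 to compound 3 (0.01 log units; within the scatter), and the same group in place of 4-cyanophenyl gives a 1.7-fold higher number from compound 1 to compound 3 (0.22 log units; within the scatter). Earlier, only the cyano and cyclopropyl groups on the same phenyl had been compared; now a change that removes the three-membered ring, brings in chlorine and alters the numbering of the substituent on the phenyl also stays within the scatter, so all three aryl groups on this nitrogen remain unseparated in this read-out. No measurement at hand gives an explanation for these numbers.

Because 3-chlorophenyl differs from both other aryl groups in the substituent and in its numbering on the phenyl, the compounds shown cannot tell the contribution of the chlorine from that of its location. They also leave open whether an aryl group on this nitrogen bearing an amine or a carboxylic acid would give a number beyond the scatter of these three compounds.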